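This account rests on a few compounds, and the source may have more. Where it says the series, first, only, none or still open, it means among the compounds named here.

Of the compounds shown here, three built on a shared core have been measured in a functional assay on U-87MG ATCC cells for antiproliferative activity against U-87 MG (Homo sapiens), read by MTT assay, with a stated time of 48 h; a higher number here means a weaker inhibitor, a lower number a stronger inhibitor. Compound 1 `Cc1nc(-c2ccc(Cl)cc2)sc1C(=O)CSc1nc(-c2ccccc2)c(C#N)c(=O)[nH]1` gives 27600 nM, compound 2 `COc1ccc(-c2nc(SCC(=O)c3sc(-c4ccccc4)nc3C)[nH]c(=O)c2C#N)cc1` gives 48400 nM, and compound 3 `Cc1nc(-c2ccccc2)sc1C(=O)CSc1nc(-c2ccc(Cl)c(Cl)c2)c(C#N)c(=O)[nH]1` gives 65000 nM. Of these, only compound 1 shows a number clearly lower than that of compound 3, while compound 2 and compound 3 cannot be told apart.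

The next compound, compound 4 `Cc1nc(-c2ccccc2)sc1C(=O)CSc1nc(-c2ccccc2)c(C#N)c(=O)[nH]1`, differs from compound 3 in one place: phenyl in place of 3,4-dichlorophenyl on an aromatic carbon. This exchange lies ortho to a cyano group.

Going by the values given here, one measured step bears directly on this change, as it touches the same place. Putting 3,4-dichlorophenyl in place of 4-methoxyphenyl gave a 1.3-fold higher number from compound 2 to compound 3 (0.13 log units; within the scatter), so exchanging these two groups did not move the number measurably. Compound 1 also carries phenyl at this place and gives 27600 nM, which tilts the expectation slightly downward. Among the compounds with values here, this is thin evidence, since no measured step removes the two chlorines alone.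

No step beyond the scatter is therefore expected in this assay, and the estimated step is a 1.4-fold lower number from compound 3 to compound 4 (0.16 log units; within the scatter). Compound 4 is estimated at 45000 nM, with an expected range from 20000 nM to 100000 nM.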

Compound 4, half-maximal inhibitory concentration: 56600 nM
The estimate for compound 4 lay 1.3-fold (0.10 log units) below the measured number; the range from low to high includes it.
By their numbers in this assay, from the lowest: compounds 1, 2, 4 and 3 (each within the scatter of the next, the first and the last beyond it).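

In this assay, the place ortho to the cyano group now looks tolerant of the three aryl groups seen there: removing the two chlorines gives a 1.1-fold lower number from compound 3 to compound 4 (0.06 log units; within the scatter), and removing the methoxy gives a 1.2-fold higher number from compound 2 to compound 4 (0.07 log units; within the scatter), so phenyl, 3,4-dichlorophenyl and 4-methoxyphenyl cannot be told apart. Going by these compounds alone, the one step beyond the scatter lies elsewhere in the molecule, where hydrogen replaces chloro on an aromatic carbon, giving a 2.1-fold higher number from compound 1 to compound 4 (0.31 log units; beyond the scatter); this step is modest, but compound 1 and compound 4 both carry phenyl at the place under study, so that phenyl alone does not account for the lower number of compound 1. No measurement is available that would explain why these exchanges at the two places behave differently.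

Going by these compounds, all three groups at this place are six-membered aromatic carbon rings, so it remains open whether an amine, a carboxylic acid or a longer alkyl chain there would shift the number. On these data alone, it is also open whether the chloro step elsewhere in the molecule would recur with 3,4-dichlorophenyl or 4-methoxyphenyl at this place.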